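A few compounds are considered here, and "the series" means these few. Any claim that something is new, unique, unknown or untested is made for them only; others in the source may bear on it.

Three compounds share one core, and all three have been tested in a functional assay on A549 cells (Homo sapiens) for antiproliferative activity, read by MTT assay, with a stated time of 24 h; a higher number here means a weaker inhibitor, a lower number a stronger inhibitor. Compound 1, `COc1ccc(-c2cc(C(=O)/C=C/c3ccc(Cl)cc3)nc3cc(-c4ccccc4)nn23)cc1OC`, gives 22000 nM. That is the highest of the three numbers. Compound 3, `COc1ccc(/C=C/C(=O)c2cc(-c3cc(OC)c(OC)c(OC)c3)n3nc(-c4ccccc4)cc3n2)cc1`, gives 21200 nM, which lies within the scatter of compound 1. Compound 2, `COc1ccc(-c2cc(/C=C/C(=O)c3ccc(OC)c(OC)c3)nc3cc(-c4ccccc4)nn23)cc1`, gives 7400 nM, a number beyond the scatter below that of compound 1.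

Compound 4, `COc1ccc(-c2cc(/C=C/C(=O)c3ccccc3)nc3cc(-c4ccccc4)nn23)cc1OC`, has not yet been measured. It differs from compound 1 in one place: 2-benzoylethenyl in place of (2-(4-chlorophenyl)ethenyl)carbonyl on an aromatic carbon. The chlorine is gone and the chain is turned the other way round, so that its carbonyl sits at the aryl end, the way it does in compound 2.

Within the data shown here, no step between measured compounds matches this change, so the expectation rests on little. Because compound 2 with its turned-round chain gives 7400 nM, a modest move toward a lower number seems more likely than a move upward, though the change may well stay within the scatter. The step from compound 1 to compound 4 is expected to be a 1.8-fold lower number from compound 1 to compound 4 (0.26 log units; within the scatter). Compound 4 is therefore estimated at 12000 nM, with a range from 4000 nM to 35000 nM.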

Compound 4, half-maximal inhibitory concentration: 10700 nM
Compound 4: the middle estimate sits 1.1-fold (0.05 log units) above what was measured; the range from low to high includes it.
By their numbers in this assay, from the lowest: compounds 2, 4, 3 and 1 (each within the scatter of the next, the first and the last beyond it).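

In this assay putting 2-benzoylethenyl in place of (2-(4-chlorophenyl)ethenyl)carbonyl on this aromatic carbon gives a 2.1-fold lower number from compound 1 to compound 4 (0.31 log units; beyond the scatter) and so provides the first step read at this position, showing that the number responds to a change in this chain. The step is modest and combines two differences, as the chlorine leaves and the chain is turned the other way round, so it cannot say which difference carries the shift. Nothing available explains the shift.

From the compounds shown here alone, the separate roles of the chlorine and the chain's direction stay open, and a turned-round chain ending in 4-chlorophenyl would help to divide them. Also open, going by these compounds, is how the number would respond if a quite different group, such as an amine or a carboxylic acid, stood on this carbon in place of the chain.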